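The source may hold more compounds than are shown below. What is called first, only, known or untested is meant among the compounds shown, and "the series" means these compounds.

Working notes on the series. In an ADME assay (liver) for pharmacokinetics, with Liver microsome (Rattus norvegicus) as the target, read by LC-MS, using microsomes, tested at 2 uM (on this read-out higher numbers stand for fast clearance and lower numbers for slow clearance), compound 1 `O=C(N[C@@H]1CCCC[C@H]1O)c1cnc(OC2CCCC2)c(-c2cc(C(F)(F)F)ccc2Cl)c1` gives 0.367 mL/min/kg and compound 2 `O=C(N[C@@H]1CCCC[C@H]1O)c1cnc(OCC2CC2)c(-c2ccc(Cl)cc2)c1` gives 0.064 mL/min/kg. Compound 2 holds the lower of the two numbers, and the gap to compound 1 lies beyond the scatter. Within the data shown here, no measured pair differs in one place only, so the data offer no direct guide to the next step. Compound 3 `O=C(N[C@@H]1CCCC[C@H]1O)c1cnc(OCc2ccncc2)c(-c2ccc(Cl)cc2)c1` departs from compound 2 in one place: pyridin-4-yl in place of cyclopropyl on a saturated chain carbon bound to an oxygen on an aromatic ring. In this assay, among the measured compounds shown here, a modest rise is expected, close to the edge of the scatter, with compound 2 at 0.064 mL/min/kg as the lowest number so far. The estimated step of a 1.9-fold higher number from compound 2 to compound 3 (0.27 log units; within the scatter) is therefore upward and uncertain. For compound 3 the estimate is 0.12 mL/min/kg, with an expected range of 0.04 mL/min/kg to 0.36 mL/min/kg.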

Compound 3, clearance: 0.118 mL/min/kg
Compound 3: middle estimate off by 1.0-fold (0.01 log units), on the high side, and the stated range covers the measured number.
By their numbers in this assay, from the lowest: compounds 2 and 3 (each within the scatter of the next); then compound 1.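

At the saturated chain carbon bound to an oxygen on an aromatic ring, the series now has its first comparison that differs in one place only: in this assay, pyridin-4-yl in place of cyclopropyl gives a 1.8-fold higher number from compound 2 to compound 3 (0.27 log units; within the scatter). A six-membered aromatic ring with one hetero atom and a hydrogen-bond acceptor can therefore stand at this position, with compound 2 and compound 3 not separable on this read-out. No supporting measurement bears on why the two cannot be told apart.

Compound 1 differs from these compounds in more than one place, so it gives no separate reading of this position. Going by these compounds, it remains open how an amine, a carboxylic acid or a longer chain at the same saturated chain carbon would read in this assay.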